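The source may hold more compounds than are shown below. What is called first, only, known or untested is meant among the compounds shown, and "the series" means these compounds.

Of the compounds shown here, three built on a shared core have so far been measured in a physicochemical assay for lipophilicity, at pH 7.4; on this read-out higher numbers stand for higher lipophilicity and lower numbers for lower lipophilicity. Compound 1, `CNC(=O)c1cc(C(=O)N[C@H]2[C@@H]3COC[C@@H]32)cc2c1OC[C@H]2c1cccc(OC)c1`, gives 3.2, the second highest of the three numbers. Nearest to it is compound 3, `CNC(=O)c1cc(C(N)=O)cc2c1OC[C@H]2c1ccccc1`, which gives 2.7, a lower reading that lies beyond the usual scatter. Furthest from it is compound 2, `CC[C@@]1(c2ccccc2)COc2c(C(=O)NC)cc(C(=O)N[C@H]3[C@@H]4COC[C@@H]43)cc21`, which gives 4.2, a higher reading, again beyond the scatter. No two of these measured compounds differ in only one place, so their gaps are read simply as what the two values show.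

Compound 4, `CNC(=O)c1cc(C(=O)N[C@H]2[C@@H]3COC[C@@H]32)cc2c1OC[C@H]2C1CCOCC1`, has not yet been measured in this assay. It differs from compound 1 in one place: oxan-4-yl in place of 3-methoxyphenyl on a saturated ring carbon. For this change a clear downward step in this assay is expected, larger than the scatter, rather than no change. Compound 4 is therefore estimated at 2, within a range from 1.4 to 2.6. That estimate corresponds to an expected step of a number 1.20 log units lower from compound 1 to compound 4 (beyond the scatter) in this assay.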

Compound 4, distribution coefficient: 2.1
Compound 4: the middle estimate sits 0.10 log units below what was measured, and the stated range covers the measured number.
By their numbers in this assay, from the lowest: compound 4; then compound 3; then compound 1; then compound 2.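

Among the compounds shown here, this is the first comparison that differs in only one place: on a saturated ring carbon, two ring bonds from the ring oxygen, oxan-4-yl in place of 3-methoxyphenyl gives a number 1.10 log units lower from compound 1 to compound 4 (beyond the scatter) in this assay and so shows that the read-out responds to the group held at this position. The step comes with an aromatic ring of carbon only leaving and a non-aromatic ring with one hetero atom entering, while the counts of hydrogen-bond donors and acceptors stay the same and neither group carries a net charge. Nothing available explains the size of this step.

The ring type and the ring oxygen change together here, so their shares in the step cannot be separated. The compounds shown leave open how a cyclohexyl group, or a piperidin-4-yl group carrying an amine, would read at this position.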